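Notes on the ethylsulfonyl analogue of compound 2

A few compounds are considered here, and "the series" means these few. Any claim that something is new, unique, unknown or untested is made for them only; others in the source may bear on it.

Compound 1 `CS(=O)(=O)N1CCC2(CC1)OOC1(CCN(S(C)(=O)=O)CC1)OO2`: > 100 ug/mL
Compound 2 `CS(=O)(=O)N1CCC2(CC1)OOC1(CCCC1)OO2`: > 100 ug/mL
Compound 3 `CS(=O)(=O)N1CCC2(CC1)OOC1(CCCCCC1)OO2`: > 100 ug/mL

All three entries are limits, not numbers, in a functional assay on Huh-7 cells (Homo sapiens) for cytotoxicity, read by MTT assay, with a stated time of 72 h; a higher number here means that more compound is tolerated, a lower number that less compound is tolerated. Compound 2 stands only at a limit, > 100 ug/mL, so it offers no number to step from.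

Compound 4 `CCS(=O)(=O)N1CCC2(CC1)OOC1(CCCC1)OO2` differs from compound 2 by methyl in place of hydrogen on a saturated chain carbon bound to a sulfonyl sulfur, which is methyl in place of hydrogen on a saturated chain carbon bound to a sulfonyl sulfur, turning methylsulfonyl into ethylsulfonyl. Going by the values given here, no step between measured compounds is available to size this change. In this assay no step beyond the usual scatter is expected, in either direction, given (the limit of > 100 ug/mL in this assay, at which 3 of the 3 values shown sit). The estimated step of a number no higher from compound 2 to compound 4 (the limit leaves the size open) is expected to stay within that scatter. For compound 4 the estimated value is 100 ug/mL, with an expected range of 60 ug/mL to 200 ug/mL.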

Compound 4, half-maximal cytotoxic concentration: > 100 ug/mL
Compound 4 ended at the assay's limit; the forecaster's own chance of this, stated with the estimate: 85%; the middle value sits exactly at the limit.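

Going by these compounds alone, compound 2 and compound 4 both stand only at limits in this assay, so no step between them can be read. The compounds shown leave open whether methylsulfonyl to ethylsulfonyl alters the half-maximal cytotoxic concentration at all.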